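A few compounds are considered here, and "the series" means these few. Any claim that something is new, unique, unknown or untested is made for them only; others in the source may bear on it.

Working notes on the series. Of the compounds shown here, three share one core and have been measured in a functional assay on MOLT-4 cells (Homo sapiens) for cytotoxicity, read by sulforhodamine B assay, with a stated time of 48 h, tested at 0.01 uM; a lower number here means a stronger effect, a higher number a weaker effect of the compound at the concentration tested: compound 1 `COc1ccc(-c2cc(/C=C/C(=O)c3ccc(N)cc3)[nH]n2)cc1` gives 97%, compound 2 `COc1cc(-c2cc(/C=C/C(=O)c3ccc(N)cc3)[nH]n2)cc(OC)c1OC` gives 101%, and compound 3 `COc1ccc(C(=O)/C=C/c2cc(-c3cc(OC)c(OC)c(OC)c3)n[nH]2)cc1` gives 103%. Compound 2 stands second highest of the three numbers; compound 3 is nearest, with a step of a number 2 percentage points higher from compound 2 to compound 3 (within the scatter), and compound 1 is furthest, also within the scatter. Compound 1 and compound 2 differ in more than one place, so only their two values can be compared, and those sit within the scatter of each other.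

Compound 4 `COc1ccc(-c2cc(/C=C/C(=O)c3ccc(N)cc3)[nH]n2)cc1OC` is the next compound, obtained from compound 2 by the change (hydrogen in place of methoxy on an aromatic carbon). Within the data shown here, the one step measured so far, from compound 2 to compound 3, concerns a different group at a different place and lies within the scatter; no measured step removes a methoxy group. All three values cluster near the top of the scale, so a step beyond the scatter is not expected for this change. The step from compound 2 to compound 4 is therefore estimated at a number 1 percentage points lower from compound 2 to compound 4 (within the scatter). In this assay compound 4 is expected to give 100%, with a range from 91% to 109%.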

Compound 4, a percentage reported as activity, at one concentration (the size of the read-out at that concentration, not a potency): 108%
For compound 4 the middle estimate is 8 percentage points below the measured one; the range from low to high includes it.
By their numbers in this assay, from the lowest: compounds 1, 2, 3 and 4 (each within the scatter of the next, the first and the last beyond it).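

Hydrogen in place of methoxy on the ring of compound 2 gives a number 7 percentage points higher from compound 2 to compound 4 (within the scatter), whereas methoxy in place of hydrogen on the ring of compound 1 gives a number 11 percentage points higher from compound 1 to compound 4 (beyond the scatter), a modest step and the first in the series to lie beyond the scatter. In this assay, among these compounds, the number at this kind of ring position, ortho to a methoxy group and meta to a large group, therefore depends on which compound the change is read from, and only the step from the single-methoxy compound can be told from the scatter. Nothing available explains either step.

The compounds shown leave open whether a hydroxyl group or a chlorine atom on this carbon would change the number. They also leave open whether the modest step from compound 1 would hold at a concentration other than the one tested.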